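A few compounds are considered here, and "the series" means these few. Any claim that something is new, unique, unknown or untested is made for them only; others in the source may bear on it.

Measured in a functional assay on HOS cells (Homo sapiens) for antiproliferative activity, with a stated time of 72 h; on this read-out lower numbers stand for stronger inhibition and higher numbers for weaker inhibition:
- Compound 1 `OC[C@H]1O[C@@H](n2cnc3c(NCc4ccc(F)cc4)ncnc32)[C@H](O)[C@@H]1O`: 13200 nM
- Compound 2 `Cc1ccc(CNc2ncnc3c2ncn3[C@@H]2O[C@H](CO)[C@@H](O)[C@H]2O)cc1`: > 166000 nM (a limit of the assay, not a number)
- Compound 3 `OC[C@H]1O[C@@H](n2cnc3c(NCc4ccc(Cl)cc4Cl)ncnc32)[C@H](O)[C@@H]1O`: > 166000 nM (a limit of the assay, not a number)

Compound 3 has no number of its own and sits at the limit of > 166000 nM in this assay, at which 2 of the 3 values shown sit. Compound 4 `OC[C@H]1O[C@@H](n2cnc3c(NCc4ccc(Cl)c(Cl)c4)ncnc32)[C@H](O)[C@@H]1O` keeps the shared core and changes one group: 3,4-dichlorophenyl in place of 2,4-dichlorophenyl on a saturated chain carbon bound to a nitrogen on an aromatic ring. The same difference, cut one bond further out, reads 2,4-dichlorobenzyl to 3,4-dichlorobenzyl.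

Among the compounds with values here, two measured steps bear on this change, and both are large and beyond the scatter. One is an at least 12-fold higher number from compound 1 to compound 2 (1.09 log units; beyond the scatter). Within the data shown here, the other, which brings in a dichlorophenyl group like the one in compound 4, is an at least 12-fold higher number from compound 1 to compound 3 (1.09 log units; beyond the scatter). Neither step moves a chlorine, so neither gives a direct size for this change, and a step that the two limits leave unreadable from compound 2 to compound 3 adds nothing on size.

Compound 4 is therefore expected to stay at the weak end of this assay, and a result at the same limit is quite likely. Only a move to lower numbers could be read, and it is expected to be modest. The estimated step is an at least 1.6-fold lower number from compound 3 to compound 4 (0.22 log units; that floor lies within the scatter). The estimate for compound 4 is 100000 nM, with an expected range from 20000 nM to 300000 nM.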

Compound 4, half-maximal inhibitory concentration: > 166000 nM
Compound 4: a limit, no number (the forecaster's own chance of this, stated with the estimate: 55%); at least 1.6-fold (0.22 log units) between middle value and limit.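

In this assay, moving one chlorine from the 2,4-dichlorophenyl pattern to the 3,4-dichlorophenyl pattern still gives no number, and compound 4 sits at a limit of the assay, as compound 3 does: the limit of > 166000 nM in this assay, at which 3 of the 4 values shown sit.

With only limits on both sides, the steps to compound 4 from compound 3 and from compound 2 cannot be read, so the effect of moving this chlorine has no measured size. The one readable step is an at least 12-fold higher number from compound 1 to compound 4 (1.09 log units; beyond the scatter), which shows that a second dichlorophenyl pattern on the saturated chain carbon also lies far from the 4-fluorophenyl result, leaving 4-fluorophenyl as the only group shown here with a measured number.

The compounds shown leave open how far compound 3 and compound 4 actually lie apart, since neither has a value of its own. They also leave open whether the single fluorine is what matters, which a 4-chlorophenyl or 3-fluorophenyl group could test, and whether a longer chain in place of the benzyl would give a number.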